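Series notes: the step from compound 3 to compound 4

A few compounds are considered here, and "the series" means these few. Any claim that something is new, unique, unknown or untested is made for them only; others in the source may bear on it.

In a functional assay on CHO cells with sphingosine 1-phosphate receptor 2 (Homo sapiens) as the target, read by GTPgammaS binding (on this read-out lower numbers stand for an effect already at smaller amounts and higher numbers for an effect only at larger amounts of compound), compound 1 `CC[C@H](C)Oc1ccc(-c2nc(-c3ccc(CCC(=O)O)cc3C)no2)cc1C#N` gives only a limit, > 10000 nM. Compound 2 `Cc1cc(CCC(=O)O)ccc1-c1noc(-c2ccc(OC(C(F)(F)F)C(F)(F)F)c(C#N)c2)n1` likewise gives only a limit, > 10000 nM. The step that the two limits leave unreadable from compound 1 to compound 2 therefore cannot be read. Compound 3 `CCCCc1ccc(-c2nc(-c3ccc(CCC(=O)O)cc3C)no2)nc1` also returns only a limit, > 10000 nM, so it stands with the others at the limit of > 10000 nM in this assay, at which 3 of the 3 values shown sit. Compound 4 `Cc1cc(CCC(=O)O)ccc1-c1noc(-c2ccc(C(F)(F)C(C)C)cn2)n1` differs from compound 3 by 1,1-difluoro-2-methylpropyl in place of butyl on an aromatic carbon. Within the data shown here, no measured step bears directly on this change; the one measured step is unreadable, and every value so far sits at the limit. Compound 4 is therefore expected to stay near that limit, with an expected step that the limit leaves unreadable from compound 3 to compound 4 that carries no direction beyond the scatter. The estimate for compound 4 in this assay is 15000 nM, between 4000 nM and 60000 nM.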

Compound 4, half-maximal effective concentration: > 10000 nM
Compound 4 was reported as a limit (the forecaster's own chance of this, stated with the estimate: 75%); the middle value is on the limit's open side.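

Compound 3 and compound 4 both give only limits in this assay, so no step can be read for 1,1-difluoro-2-methylpropyl in place of butyl: the limit of > 10000 nM in this assay, at which 4 of the 4 values shown sit.

The compounds shown leave open how far any of them lies past that limit in this assay.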